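Diethylamino for amino on a compound at the limit

The source may hold more compounds than are shown below. What is called first, only, known or untested is meant among the compounds shown, and "the series" means these compounds.

In a functional assay on SK-MEL-28 cells (Homo sapiens) for inhibition (on this read-out lower numbers stand for stronger inhibition and higher numbers for weaker inhibition), compound 1 `COCCOc1cc(/C=C/c2ccc3ccccc3c2)ccc1OC` gives 2990 nM. Compound 2 `COc1ccc(/C=C/c2ccc3ccccc3c2)cc1[N+](=O)[O-]` gives only a limit, > 5000 nM. From the compounds shown here alone, compound 3 `COc1ccc(/C=C/c2ccc3ccccc3c2)cc1N` also gives only a limit, > 5000 nM, so its true position is unknown. For the measured compounds named here, the series so far is marked by the limit of > 5000 nM in this assay, at which 2 of the 3 values shown sit.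

Compound 4 `CCN(CC)c1cc(/C=C/c2ccc3ccccc3c2)ccc1OC` has diethylamino in place of amino on an aromatic carbon. Three measured steps exchange groups at this place: an at least 1.6-fold higher number from compound 1 to compound 2 (0.22 log units; that floor lies within the scatter), an at least 1.6-fold higher number from compound 1 to compound 3 (0.22 log units; that floor lies within the scatter) and a step that the two limits leave unreadable from compound 2 to compound 3. None shows a change beyond the scatter, so no clear step in either direction is expected in this assay. The expected change is a number no higher from compound 3 to compound 4 (the limit leaves the size open). Compound 4 is expected near 5000 nM, with an estimated range from 2000 nM to 12000 nM.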

Compound 4, half-maximal inhibitory concentration: > 5000 nM
Compound 4: no number, only a limit (the forecaster's own chance of this, stated with the estimate: 60%); the middle value sits exactly at the limit.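

Like amino and nitro, diethylamino at this place yields only a limit in this assay, so a third group, and the first of these with no hydrogen-bond donor in place of amino, gives no number: the limit of > 5000 nM in this assay, at which 3 of the 4 values shown sit. The steps from compound 2 and from compound 3 to compound 4 cannot be read, as both ends are limits. The one readable step is an at least 1.6-fold higher number from compound 1 to compound 4 (0.22 log units; that floor lies within the scatter), so no order among these groups is shown. Still open, from the compounds shown here alone, is whether a hydroxy group or a longer ether chain here would give a number, and where compound 2, compound 3 and compound 4 truly lie.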